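Taking the Methoxy Group off Compound 1

The source may hold more compounds than are shown below. What is called first, only, known or untested is meant among the compounds shown, and "the series" means these compounds.

In a functional assay on CaEs17 cells (Homo sapiens) for inhibition, read by MTT assay (on this read-out lower numbers stand for stronger inhibition and higher numbers for weaker inhibition), compound 1 `C=C1C(=O)[C@@]23C(=O)OC[C@]4([C@@H](OC(C)=O)CCC(C)(C)[C@H]4C=O)[C@@H]2CC[C@H]1[C@H]3OC(=O)c1ccc(OC)cc1` gives 1960 nM and compound 2 `C=C1C(=O)[C@@]23C(=O)OC[C@]4([C@@H](OC(C)=O)CCC(C)(C)[C@H]4C=O)[C@@H]2CC[C@H]1[C@H]3OC(=O)c1ccc(C)cc1` gives 1830 nM. Among the measured compounds shown here, these are the only two numbers so far, and they lie within the scatter of each other, so compound 1 cannot be ranked against compound 2. Compound 3 `C=C1C(=O)[C@@]23C(=O)OC[C@]4([C@@H](OC(C)=O)CCC(C)(C)[C@H]4C=O)[C@@H]2CC[C@H]1[C@H]3OC(=O)c1ccccc1` keeps the shared core of compound 1 but has hydrogen in place of methoxy on an aromatic carbon, para to a large group: hydrogen in place of methoxy on an aromatic carbon. For the measured compounds named here, the one measured step that bears on this is a 1.1-fold lower number from compound 1 to compound 2 (0.03 log units; within the scatter), where methyl replaces methoxy. Going by the values given here, it is a different replacement, and no measured step removes the group outright, so it is only a rough guide. Going by that single step, no change beyond the scatter is expected in this assay, and the estimated step of a 1.0-fold lower number from compound 1 to compound 3 (0.01 log units; within the scatter) reflects this. Compound 3 is expected at about 1900 nM, with an estimated range of 900 nM to 4000 nM.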

Compound 3, half-maximal inhibitory concentration: 1990 nM
For compound 3 the middle estimate is 1.0-fold (0.02 log units) below the measured one, and the stated range covers the measured number.
By their numbers in this assay, from the lowest: compounds 2, 1 and 3 (each within the scatter of the next).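

In this assay, hydrogen in place of methoxy gives (a 1.0-fold higher number from compound 1 to compound 3 (0.01 log units; within the scatter)), and hydrogen in place of methyl gives (a 1.1-fold higher number from compound 2 to compound 3 (0.04 log units; within the scatter)). Among the compounds shown here, the earlier step compared only two groups with each other, whereas these steps add the case with no group at all on this aromatic carbon, and methoxy, methyl and hydrogen cannot be told apart here. No measured evidence is available to explain this result.

Going by these compounds, whether the same holds for an amine, a carboxylic acid or a longer chain on this carbon stays open. Also open is how much the aromatic ring itself matters, since every compound shown keeps that ring and its ester link to the shared core.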